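The source may report more compounds than this note shows. Statements on the series, on what has been measured and on what is new or still open speak of the compounds shown alone.

Three compounds have been measured in an assay for binding affinity to Apoptosis regulator Bcl-2 (Homo sapiens), read by fluorescence polarization, with stated times of 30 min and 20 min, tested at 100 uM; on this read-out higher numbers stand for more inhibition at the one concentration tested (going by the name of the read-out) and lower numbers for less inhibition:

compound 1 `COc1ccc(Oc2ccccc2-c2ccsc2S(=O)(=O)N2CCN(C(=S)Nc3cc(C(F)(F)F)cc(C(F)(F)F)c3)CC2)cc1OC`: 25%
compound 2 `COc1ccc(Oc2ccccc2-c2ccsc2S(=O)(=O)N2CCN(C(=S)Nc3ccc(Cl)cc3)CC2)cc1OC`: 18%
compound 3 `O=S(=O)(c1sccc1-c1ccccc1Oc1ccc(O)c(O)c1)N1CCN(C(=S)Nc2ccc(Cl)cc2)CC1`: 2%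

Compound 1 and compound 2 carry different groups on the shared core, but the difference between the two cores is not broken down here; their two values lie within the usual scatter of each other. Compound 2 and compound 3 differ in one place only: 3,4-dihydroxyphenyl in place of 3,4-dimethoxyphenyl on an oxygen on an aromatic ring. That change made a number 16 percentage points lower from compound 2 to compound 3 (beyond the scatter).

Compound 4 `O=S(=O)(c1sccc1-c1ccccc1Oc1ccc(O)c(O)c1)N1CCN(C(=S)Nc2cc(C(F)(F)F)cc(C(F)(F)F)c2)CC1` has not yet been measured. It arises from compound 1 by the same change, (3,4-dihydroxyphenyl in place of 3,4-dimethoxyphenyl on an oxygen on an aromatic ring), at the same place on the same kind of oxygen. Because the earlier change made a number 16 percentage points lower from compound 2 to compound 3 (beyond the scatter), a step of similar size is expected here, a number 16 percentage points lower from compound 1 to compound 4 (beyond the scatter). Compound 4 is therefore expected to give 9% in this assay, with a likely range from -4% to 22%.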

Compound 4, a percentage reported as inhibition, at one concentration (the size of the read-out at that concentration, not a potency): 20%
Beside the measured number, compound 4's estimate is 11 percentage points below it, within the range that was stated.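

In this assay, placing 3,4-dihydroxyphenyl where 3,4-dimethoxyphenyl stood gives a number 5 percentage points lower from compound 1 to compound 4 (within the scatter). Set beside the earlier step, the two cores cannot be told apart: the same change on two cores in this assay, a number 16 percentage points lower (beyond the scatter) from compound 2 to compound 3 and a number 5 percentage points lower (within the scatter) from compound 1 to compound 4, 11 percentage points apart, within the scatter of two such steps. Among the compounds shown here, this fits a change that carries from one core to the other, but with only two pairs, one step beyond the scatter and one within it, it does not show that the step has a fixed size or that it would hold on any further core.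

The compounds shown leave open what other groups on that phenyl ring, such as an amine or a carboxylic acid, would do. They also leave open how these compounds rank as true potencies, since each read-out comes from a single concentration.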